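Fluorosulfonyl benzyl ethers on a dihydrotriazine core

This account rests on a few compounds, and the source may have more. Where it says the series, first, only, none or still open, it means among the compounds named here.

Measured compounds:
compound 1, `CC1(C)N=C(N)N=C(N)N1c1ccc(OCc2ccc(S(=O)(=O)F)cc2)c(Cl)c1`, 7.58
compound 2, `CC1(C)N=C(N)N=C(N)N1c1ccc(OCc2ccc(S(=O)(=O)F)c(Cl)c2)c(Cl)c1`, 7.43
compound 3, `CC1(C)N=C(N)N=C(N)N1c1ccc(OCc2ccccc2S(=O)(=O)F)c(Cl)c1`, 7.43

The read-out for all three is an assay on isolated protein for inhibition of Dihydrofolate reductase (Mus musculus); on this read-out lower numbers stand for lower potency and higher numbers for higher potency (the scale is a negative logarithm). Compound 1 and compound 2 share a core and differ by one change, (chloro in place of hydrogen on an aromatic carbon). The step that this change made, a number 0.15 log units lower from compound 1 to compound 2 (within the scatter), lies within the scatter, so the two values are treated as level. Compound 3 carries a core of the same atoms joined differently; the difference between the two cores is not broken down here. In this assay compound 3 gives 7.43, which is within the scatter of both compound 1 and compound 2.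

Compound 4, `CC1(C)N=C(N)N=C(N)N1c1ccc(OCc2ccc(Cl)cc2S(=O)(=O)F)c(Cl)c1`, has not yet been measured in this assay . It differs from compound 3 by chloro in place of hydrogen on an aromatic carbon. Within the data shown here, this is the same kind of change as the one from compound 1 to compound 2, but the surroundings differ: in compound 2 the chloro sits ortho to a fluorosulfonyl group and meta to a large group, in compound 4 it sits meta to a fluorosulfonyl group and para to a large group. Among the measured compounds shown here, with only the one earlier step as a guide, the step from compound 3 to compound 4 is expected to be small, about a number 0.10 log units lower from compound 3 to compound 4 (within the scatter), because the same kind of change gave a number 0.15 log units lower from compound 1 to compound 2 (within the scatter). Compound 4 is therefore estimated at 7.33 in this assay , with a range from 6.9 to 7.75.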

Compound 4, logarithm of the reciprocal of the active concentration, log(1/C): 7.52
Compound 4: the middle estimate sits 0.19 log units below what was measured; the measured number falls inside the stated range.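

Working notes on the chloro step. In this assay, chloro in place of hydrogen on an aromatic carbon, here meta to a fluorosulfonyl group and para to a large group, gives a number 0.09 log units higher from compound 3 to compound 4 (within the scatter). Set beside the earlier step, the change carries from one core to the other with no difference that can be told apart from the scatter: the same change on two cores in this assay, a number 0.15 log units lower (within the scatter) from compound 1 to compound 2 and a number 0.09 log units higher (within the scatter) from compound 3 to compound 4, 0.24 log units apart, within the scatter of two such steps

Both steps are small enough to be read as level, so this pair shows only that adding the chloro left the values within the scatter on these two cores, and it fixes neither a direction nor a size for the change, nor does it reach any core beyond these two, especially as the chloro stands in a different place on each.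

How a methoxy, a nitrile or an amine would stand on the same aromatic carbon stays open, since chloro is the only group entering in the compounds shown. Also open, as far as these compounds go, is how the series would read in this assay with a carboxylic acid or a sulfonamide in place of the fluorosulfonyl group, which all four compounds carry.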